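The source may report more compounds than this note shows. Statements on the series, on what has been measured and on what is new or still open speak of the compounds shown alone.

Compound 1 `CS(=O)(=O)Cc1nc2c(Sc3ccc(Cl)cc3)cc(Cl)cn2c1[N+](=O)[O-]` gives > 31200 nM in an ADME assay on HepG2 cells (Homo sapiens) for cytotoxicity, read by MTT assay, with a stated time of 72 h (a lower number here means that less compound is tolerated, a higher number that more compound is tolerated), which is a limit of the assay and not a number.
Compound 2 `Cc1cc(Sc2ccc(Cl)cc2)c2nc(CS(=O)(=O)c3ccccc3)c([N+](=O)[O-])n2c1` gives > 62500 nM in this assay, again only a limit.
Compound 3 `CS(=O)(=O)Cc1nc2c(Br)cc(Cl)cn2c1[N+](=O)[O-]` gives 45000 nM in this assay.

From compound 1 to compound 3 the change is bromo in place of (4-chlorophenyl)sulfanyl on an aromatic carbon. The size of this step, a step that the limit leaves unreadable from compound 1 to compound 3, cannot be read because compound 1 sits at the limit of > 31200 nM in this assay, at which 1 of the 3 values shown sits. Compound 4 `Cc1cc(Br)c2nc(CS(=O)(=O)c3ccccc3)c([N+](=O)[O-])n2c1` has not yet been measured; it arises from compound 2 by bromo in place of (4-chlorophenyl)sulfanyl on an aromatic carbon. The two cores differ in a way that is not broken down here, and the place itself differs too: in compound 1 the carbon is meta to a chloro group, in compound 2 meta to a methyl group, so this is the same kind of change rather than the same one. Among the compounds with values here, compound 2 sits at the limit of > 62500 nM in this assay, at which 1 of the 3 values shown sits, so no measured step is available for this pair either. Within the data shown here, the only guide is compound 3, which gives 45000 nM. He expects compound 4 to give about 50000 nM in this assay. The range he estimates for compound 4 runs from 20000 nM to 125000 nM. The step he expects, an at least 1.2-fold lower number from compound 2 to compound 4 (0.09 log units; that floor lies within the scatter), rests on the value of compound 3 alone and may well end at a limit again.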

Compound 4, half-maximal cytotoxic concentration: > 31200 nM
Compound 4 ended at the assay's limit; the forecaster's own chance of this, stated with the estimate: 50%; the middle value is on the limit's open side.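

In this assay, within the data shown here, compound 2 and compound 4 both end at limits of the assay, and no step between them can be read. The compounds shown leave open whether bromo in place of (4-chlorophenyl)sulfanyl changes the tolerated concentration at all.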